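The compounds below may be only part of what the source reports. "The series", "measured", "known", "first", "only" and "open" are said of these compounds alone.

Measured so far:
compound 1, `COc1cc2ncnc(Oc3ccc(NC(=O)Nc4ccc(Cl)c(C(F)(F)F)c4)c4ccccc34)c2cc1OC`, 2970 nM
compound 2, `COc1cc2ncnc(Oc3ccc(NC(=O)Nc4ccc(Cl)c(C(F)(F)F)c4)c4cccnc34)c2cc1OC`, "not determined" (no result reported)

Among the measured compounds shown here, compound 1 holds the only number in a functional assay on HUVEC cells (Homo sapiens) for inhibition, read by CellTiter-Glo, with a stated time of 72 h; on this read-out higher numbers stand for weaker inhibition and lower numbers for stronger inhibition: there compound 1 gives 2970 nM. For compound 2 no result was reported, so compound 1 stands alone on the numbers shown. Compound 3, `COc1cc2ncnc(Oc3ccc(NC(=O)Nc4cnn(C(C)C)c4)c4ccccc34)c2cc1OC`, remains to be measured. It differs from compound 1 in one place: 1-isopropyl-1H-pyrazol-4-yl in place of 4-chloro-3-(trifluoromethyl)phenyl on an amide-type nitrogen. For the measured compounds named here, no step between measured compounds exists to lean on, so the expected step is a modest one, toward somewhat stronger inhibition or none beyond the scatter, written as a 1.5-fold lower number from compound 1 to compound 3 (0.17 log units; within the scatter). Compound 3 is estimated at 2000 nM, within a range from 500 nM to 8000 nM.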

Compound 3, half-maximal inhibitory concentration: 630 nM
Beside the measured number, compound 3's estimate is 3.2-fold (0.50 log units) above it, within the range that was stated.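

On the amide-type nitrogen, the group can change substantially without loss of inhibition: in this assay, 1-isopropyl-1H-pyrazol-4-yl in place of 4-chloro-3-(trifluoromethyl)phenyl gives a 4.7-fold lower number from compound 1 to compound 3 (0.67 log units; beyond the scatter). A five-membered aromatic ring with 2 hetero atoms is therefore accepted here and gives stronger inhibition than the halogenated phenyl ring. Nothing measured here accounts for this step.

The compounds shown leave open whether the pyrazole ring or its isopropyl group carries the change. A methyl or cyclopropyl group in place of isopropyl, or an unsubstituted phenyl ring on the same nitrogen, would help separate the two.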